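Aryl change on the shared core: compound 1 to compound 4

The compounds below may be only part of what the source reports. "The series", "measured", "known", "first", "only" and "open" are said of these compounds alone.

Measured so far in a functional assay on HL-60 cells (Homo sapiens) for cytotoxicity, read by CellTiter-Blue, with a stated time of 48 h; a lower number here means a stronger inhibitor, a higher number a weaker inhibitor:
compound 1 `CCOC(=O)CC1C(C(=O)OCC)=C(N)Oc2ccc(-c3cc(F)cc(F)c3)cc21` — 35900 nM
compound 2 `C#CCOC(=O)CC1C(C(=O)OCC#C)=C(N)Oc2ccc(-c3cccc(N)c3)cc21` — 1240 nM
compound 3 `C#CCOC(=O)CC1C(C(=O)OCC)=C(N)Oc2ccc(-c3ccc(N)cc3)cc21` — 10500 nM

Compound 1 stands at the highest number of the three. Compound 3 sits at 10500 nM and compound 2 at 1240 nM; both gaps to compound 1 lie beyond the scatter. Among the compounds with values here, neither compound 2 nor compound 3 differs from compound 1 in one place only, so no single step between measured compounds can be isolated. In each of them, a nitrogen-bearing ring stands where compound 1 carries 3,5-difluorophenyl, but the ester groups change as well, so the effect of the aryl change alone is not pinned down.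

Compound 4 `CCOC(=O)CC1C(C(=O)OCC)=C(N)Oc2ccc(-c3cccc(NC)c3)cc21` has not been measured. It differs from compound 1 in one place: 3-(methylamino)phenyl in place of 3,5-difluorophenyl on an aromatic carbon. The incoming group brings one hydrogen-bond donor and one acceptor where the outgoing group had none, as counted above.

On the numbers of compound 2 and compound 3, a lower number than compound 1 is expected for compound 4, a step of a 5.1-fold lower number from compound 1 to compound 4 (0.71 log units; beyond the scatter) beyond the scatter, though the ester differences leave this uncertain. Compound 4 is estimated at 7000 nM, with a range from 2000 nM to 25000 nM.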

Compound 4, half-maximal inhibitory concentration: 7450 nM
Compound 4: the middle estimate sits 1.1-fold (0.03 log units) below what was measured; the measured number falls inside the stated range.
By their numbers in this assay, from the lowest: compound 2; then compounds 4 and 3 (each within the scatter of the next); then compound 1.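

In this assay, within the data shown here, with the ester groups held as in compound 1, the change to 3-(methylamino)phenyl gives a 4.8-fold lower number from compound 1 to compound 4 (0.68 log units; beyond the scatter), the first reading of an aryl change at this position free of any ester change. Among these compounds, the aryl group at this position therefore moves the number by itself, so the gaps seen for the earlier compounds need not rest on their esters alone. Both groups have 8 heavy atoms, so this step comes with no change in that count, while the entering group carries a hydrogen-bond donor and acceptor and the leaving group carries neither; nothing supplied here gives a measured reason for the step.

This single step cannot separate the loss of the two fluorines from the arrival of the methylamino group, and an unsubstituted phenyl on the same core would help to divide the two. On these data alone, a dimethylamino group in place of the methylamino group would test whether the hydrogen on that nitrogen matters, and how the aryl and ester changes combine also stays open.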